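The compounds below may be only part of what the source reports. "The series", "measured", "known", "first", "only" and "open" are said of these compounds alone.

Compound 1 `Cn1c(=O)c(S(=O)(=O)c2ccc(F)cc2F)cc2cnc(Nc3ccc4[nH]ncc4c3)nc21` carries a 2,4-difluorophenyl sulfone on the shared core and a 1H-indazol-5-yl group on the aminoaryl nitrogen. In a functional assay on K562 cells (Homo sapiens) for inhibition, read by trypan blue exclusion, with a stated time of 72 h (a lower number here means a stronger inhibitor, a higher number a weaker inhibitor), compound 1 gives 50000 nM, the highest number of the three measured compounds, and so the weakest inhibitor among them. For the measured compounds named here, compound 2 `Cn1c(=O)c(S(=O)(=O)c2ccc(F)cc2)cc2cnc(Nc3ccc4[nH]ncc4c3)nc21` gives 10000 nM in this assay, and the single change between them, hydrogen in place of fluoro on an aromatic carbon, is worth a 5.0-fold lower number from compound 1 to compound 2 (0.70 log units; beyond the scatter). Compound 3 `Cn1c(=O)c(S(=O)(=O)c2ccc(F)cc2N)cc2cnc(Nc3ccc4[nH]ccc4c3)nc21` gives 2000 nM in this assay, but it differs from compound 1 in two places, so no single step can be read from that pair.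

Compound 4 `Cn1c(=O)c(S(=O)(=O)c2ccc(F)cc2F)cc2cnc(Nc3ccncn3)nc21` is compound 1 with the change (pyrimidin-4-yl in place of 1H-indazol-5-yl on a nitrogen on an aromatic ring). Going by the values given here, none of the measured steps touches the aminoaryl nitrogen, so nothing in the measured data speaks to this change directly; the only guidance is that compound 1 already sits at the top of the range. The expected step of a 1.2-fold higher number from compound 1 to compound 4 (0.08 log units; within the scatter) is therefore small and uncertain, with the number for compound 4 estimated at 60000 nM in this assay, between 15000 nM and 250000 nM, and a real chance that only a limit is reported.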

Compound 4, half-maximal inhibitory concentration: 30000 nM
Compound 4: the middle estimate sits 2.0-fold (0.30 log units) above what was measured, and the stated range covers the measured number.
By their numbers in this assay, from the lowest: compound 3; then compound 2; then compounds 4 and 1 (each within the scatter of the next).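

For the compounds shown here, this is the first measured step at the aminoaryl nitrogen, and it comes out small: in this assay, the swap gives a 1.7-fold lower number from compound 1 to compound 4 (0.22 log units; within the scatter). The two numbers therefore cannot be told apart, even though the groups differ clearly: 1H-indazol-5-yl has two rings, 9 heavy atoms and 1 hydrogen-bond donor, while pyrimidin-4-yl has one ring, 6 heavy atoms and 0 hydrogen-bond donors. With the 2,4-difluorophenyl sulfone in place, this position therefore accepts the swap without a readable shift in the number, and no measurement offered here bears on why.

Going by these compounds, it remains open whether the same swap would also leave the number in place with the 4-fluorophenyl sulfone of compound 2, or with the amino-bearing sulfone of compound 3. On these data alone, it is also open whether another group on this nitrogen, such as a plain phenyl ring or a pyridin-3-yl ring, would move the number beyond the scatter.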